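Chain homologation in a triazole series: cytotoxicity notes

A few compounds are considered here, and "the series" means these few. Any claim that something is new, unique, unknown or untested is made for them only; others in the source may bear on it.

Measured so far:
compound 1 `CCC[C@H](CCn1cncn1)c1ccc(C)cc1`: 47.2 ug/mL
compound 2 `CCC[C@@H](CCn1cncn1)c1ccc(C)cc1`: 74.1 ug/mL

Among the measured compounds shown here, in an ADME assay on RD cells (Homo sapiens) for cytotoxicity, read by MTT assay, with a stated time of 3 days (on this read-out higher numbers stand for lower toxicity in this test and lower numbers for higher toxicity in this test), compound 1 gives 47.2 ug/mL; the only comparator is compound 2 at 74.1 ug/mL, and a 1.6-fold higher number from compound 1 to compound 2 (0.20 log units; within the scatter). That step rests on (the fact that compounds 1 and 2 differ only in the configuration as drawn). Compound 3 `CCCC[C@H](CCn1cncn1)c1ccc(C)cc1` carries methyl in place of hydrogen on a saturated chain carbon, four bonds along the chain from an aromatic carbon. For the measured compounds named here, no measured step touches chain lengthening; the single step in hand is a change of configuration and stays within the scatter, so nothing beyond the scatter is expected in this assay for this change either. Compound 3 is therefore estimated at 45 ug/mL, range 20 ug/mL to 100 ug/mL, meaning a 1.0-fold lower number from compound 1 to compound 3 (0.02 log units; within the scatter) is expected.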

Compound 3, half-maximal cytotoxic concentration: 26.5 ug/mL
The estimate for compound 3 lay 1.7-fold (0.23 log units) above the measured number, and the stated range covers the measured number.
By their numbers in this assay, from the lowest: compounds 3, 1 and 2 (each within the scatter of the next, the first and the last beyond it).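

In this assay, among the compounds shown here, the first chain change, propyl to butyl, gives a 1.8-fold lower number from compound 1 to compound 3 (0.25 log units; within the scatter). At this saturated chain carbon, four bonds along the chain from an aromatic carbon, methyl in place of hydrogen therefore stays within the scatter, as the change of configuration did. Nothing in hand bears on the cause of this step.

From the compounds shown here alone, whether a pentyl or longer chain, or an amine or a carboxylic acid at this place, would move the number beyond the scatter remains open. Also open, going by these compounds, is whether configuration counts any more with the butyl chain than with the propyl chain.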